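A few compounds are considered here, and "the series" means these few. Any claim that something is new, unique, unknown or untested is made for them only; others in the source may bear on it.

Compound 1 `C[S+]([O-])/C=C/c1ccc(-c2cnc(C(=O)CCCCCCc3ccccc3)o2)nc1`: 0.9 nM
Compound 2 `CSC(=O)CCCCc1cnc(C(=O)CCCCCCc2ccccc2)o1`: 1.5 nM

Of the compounds shown here, two sharing the same core have been measured in an assay for inhibition of Fatty-acid amide hydrolase 1 (Rattus norvegicus), using a Dixon plot, with a stated time of 6 h; a higher number here means a weaker inhibitor, a lower number a stronger inhibitor. Compound 1 gives 0.9 nM and compound 2 gives 1.5 nM. Compound 2 sits alongside compound 1: the gap between the two numbers lies within the scatter, so the two cannot be set apart on these data, and both are strong inhibitors in this assay.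

Compound 3 `O=C(CCCCCCc1ccccc1)c1ncc(CCCCCBr)o1` has not yet been measured. It differs from compound 2 in one place: bromomethyl in place of (methylsulfanyl)carbonyl on a saturated chain carbon, four bonds along the chain from an aromatic carbon. Going by the values given here, no measured pair of compounds shows this change, so its effect on this assay is unknown from the data at hand.

The two measured compounds differ widely in their chain terminus and ring substitution yet give numbers within the scatter of each other, which suggests that the end of the chain is not decisive here. Compound 3 is therefore expected to stay close to compound 2, with a step from compound 2 to compound 3 of a 2.0-fold higher number from compound 2 to compound 3 (0.30 log units; within the scatter), leaning toward a weaker inhibitor. The estimate for compound 3 in this assay is 3 nM, with a range from 1 nM to 10 nM.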

Compound 3, inhibition constant: 6 nM
The estimate for compound 3 lay 2.0-fold (0.30 log units) below the measured number, and the stated range covers the measured number.
By their numbers in this assay, from the lowest: compounds 1 and 2 (each within the scatter of the next); then compound 3.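

In this assay the change from (methylsulfanyl)carbonyl to bromomethyl on a saturated chain carbon, four bonds along the chain from an aromatic carbon, gives a 4.0-fold higher number from compound 2 to compound 3 (0.60 log units; beyond the scatter) and is a modest step beyond the scatter. Going by these compounds alone, this is the first one-place comparison, and it shows that the group at this chain end does register in this assay, something the two earlier compounds, which differ in more than one place, could not show. Compound 3 at 6 nM nevertheless remains a strong inhibitor, so (methylsulfanyl)carbonyl is not required for strong inhibition here, and no accompanying measurement bears on what lies behind the step.

The compounds shown leave open whether another group at this chain end, such as a carboxylic acid, an amine or a nitrile, would give a number nearer that of compound 2 or nearer that of compound 3. They also leave open whether a shorter or longer chain carrying bromomethyl would change the size of this step.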